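The compounds below may be only part of what the source reports. "The series", "measured", "known", "first", "only" and "open" are said of these compounds alone.

In a functional assay on BGC-823 cells (Homo sapiens) for inhibition, read by MTT assay, with a stated time of 72 h (on this read-out lower numbers stand for stronger inhibition and higher numbers for weaker inhibition), compound 1 `O=C1/C(=C\c2ccccc2)c2c(ncn2COCc2ccccc2)CCN1Cc1ccccc1` gives 20400 nM and compound 2 `COc1cc(/C=C2\C(=O)N(Cc3ccccc3)CCc3ncn(COCc4ccccc4)c32)cc(OC)c1OC` gives 12900 nM, and a 1.6-fold lower number from compound 1 to compound 2 (0.20 log units; within the scatter) stays within the scatter. For compound 3 `O=C1/C(=C\c2ccncc2)c2c(ncn2COCc2ccccc2)CCN1Cc1ccccc1` the reading is only a limit, > 100000 nM. Compound 4 `O=C1/C(=C\c2ccc(C(F)(F)F)cc2)c2c(ncn2COCc2ccccc2)CCN1Cc1ccccc1` carries 4-(trifluoromethyl)phenyl in place of pyridin-4-yl on a double-bonded chain carbon bound to a double-bonded ring carbon. Among the compounds with values here, two measured steps bear on this change, as both introduce pyridin-4-yl at that same place: an at least 4.9-fold higher number from compound 1 to compound 3 (0.69 log units; beyond the scatter), and an at least 7.7-fold higher number from compound 2 to compound 3 (0.88 log units; beyond the scatter). Both lie beyond the scatter. Read in reverse, they point to a lower number for compound 4, whose ring, like those of compound 1 and compound 2, is a six-membered aromatic ring of carbon only. Within the data shown here, no measured compound carries 4-(trifluoromethyl)phenyl, so the range is kept wide. The expected change is an at least 6.2-fold lower number from compound 3 to compound 4 (0.79 log units; beyond the scatter), similar in size to the two measured steps. Compound 4 is estimated at 16000 nM, with an expected range from 5000 nM to 50000 nM.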

Compound 4, half-maximal inhibitory concentration: 42600 nM
Beside the measured number, compound 4's estimate is 2.7-fold (0.43 log units) below it; the range from low to high includes it.
By their numbers in this assay, from the lowest: compounds 2 and 1 (each within the scatter of the next); then compound 4. At a limit, above all of these: compound 3.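

In this assay, 4-(trifluoromethyl)phenyl in place of pyridin-4-yl gives an at least 2.3-fold lower number from compound 3 to compound 4 (0.37 log units; beyond the scatter), so a ring of carbon only at this place again brings a measurable number. That step is only a bound, as the reading for compound 3 is a limit: the limit of > 100000 nM in this assay, at which 1 of the 4 values shown sits. The substituent on the ring also matters here: trifluoromethyl in place of hydrogen on an aromatic carbon gives a 2.1-fold higher number from compound 1 to compound 4 (0.32 log units; beyond the scatter), and replacing 3,4,5-trimethoxyphenyl with 4-(trifluoromethyl)phenyl gives a 3.3-fold higher number from compound 2 to compound 4 (0.52 log units; beyond the scatter), whereas the earlier step from phenyl to 3,4,5-trimethoxyphenyl stayed within the scatter.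

The compounds shown leave open whether a single methoxy group, a chlorine or an amine on the phenyl ring would move the number in either direction. They also leave open whether pyridin-3-yl would behave like pyridin-4-yl.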